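The compounds below may be only part of what the source reports. "The series", "measured", "known", "first", "only" and "open" are said of these compounds alone.

Three compounds built on a shared core are at issue here, and only one of them has so far given a number. In a functional assay on HeLa cells (Homo sapiens) for antiproliferative activity, read by CCK-8 assay, with a stated time of 72 h (on this read-out lower numbers stand for stronger inhibition of growth and higher numbers for weaker inhibition of growth), compound 1 (`CCC1C(=O)N(C)c2cnc(-n3ccc4cc(C(=O)NC(C)C)ccc43)nc2N1c1ccn(C)n1`) gives 4350 nM. In this assay compound 2 (`CCC1C(=O)N(C)c2cnc(-n3ccc4cc(F)ccc43)nc2N1c1ccn(C)n1`) is recorded as "not active" (no number reported), so it has no single number to place it on the scale. Compound 3 (`CCCNC(=O)c1ccc2c(ccn2-c2ncc3c(n2)N(c2ccn(C)n2)C(CC)C(=O)N3C)c1`) is still unmeasured. One structural change leads to it: propylcarbamoyl in place of fluoro on an aromatic carbon. Within the data shown here, no measured pair of compounds shows what such a swap does, so the size of the step cannot be read directly from the data. The expectation is a step towards stronger inhibition in this assay, from no number at all to a measurable but modest value. Among the measured compounds shown here, the guide for this is compound 1, the only one with a number, at 4350 nM, and the new value is expected to land near it. The estimated value for compound 3 is 3500 nM, with an expected range of 1200 nM to 10000 nM.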

Compound 3, concentration for 50% growth inhibition: 6160 nM
Beside the measured number, compound 3's estimate is 1.8-fold (0.25 log units) below it, and the stated range covers the measured number.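

Compound 2 carries fluoro on the aromatic carbon where compound 3 carries propylcarbamoyl, and in this assay compound 3 gives 6160 nM while compound 2 is recorded as "not active", so the size of this swap cannot be read, though a second amide at this position now gives a number. Propyl in place of isopropyl on the amide-type nitrogen gives a 1.4-fold higher number from compound 1 to compound 3 (0.15 log units; within the scatter) and that step is within the scatter, so in this assay this position does not separate the straight chain from the branched one among these two amides. Nothing measured here explains why compounds 1 and 3 give numbers while compound 2 does not.

Still open, from the compounds shown here alone, is whether a longer chain such as butyl or a ring such as cyclopropyl on the amide nitrogen would also leave the number in the same region, since only two small chains appear there. Also open, going by these compounds, is what other groups on the same aromatic carbon would give, such as a carboxylic acid, an amine or a dimethylamide, which has no amide hydrogen.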